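A Longer Oxygen-Bearing Side Chain on the Shared Core

A few compounds are considered here, and "the series" means these few. Any claim that something is new, unique, unknown or untested is made for them only; others in the source may bear on it.

Among the compounds with values here, compound 1 `CCCCc1cn(CCNc2nonc2/C(=N/O)Nc2ccc(F)c(Br)c2)nn1` gives 830 nM in an assay on isolated protein for inhibition of Indoleamine 2,3-dioxygenase 2 (Homo sapiens) (a lower number here means a stronger inhibitor, a higher number a weaker inhibitor), the second highest of the three numbers measured so far. Compound 2 `OCCc1cn(CCNc2nonc2/C(=N/O)Nc2ccc(F)c(Br)c2)nn1` gives 1170 nM and compound 3 `CC(O)c1cn(CCNc2nonc2/C(=N/O)Nc2ccc(F)c(Br)c2)nn1` gives 362 nM. Compound 4 `CC(OCCO)c1cn(CCNc2nonc2/C(=N/O)Nc2ccc(F)c(Br)c2)nn1` differs from compound 1 in one place: 1-(2-hydroxyethoxy)ethyl in place of butyl on an aromatic carbon. Within the data shown here, two measured steps bear on this change. Putting 1-hydroxyethyl in place of butyl gave a 2.3-fold lower number from compound 1 to compound 3 (0.36 log units; beyond the scatter), whereas a hydroxy in place of ethyl on a saturated chain carbon gave a 1.4-fold higher number from compound 1 to compound 2 (0.15 log units; within the scatter). Because a 2.3-fold lower number from compound 1 to compound 3 (0.36 log units; beyond the scatter) was only modest and a 1.4-fold higher number from compound 1 to compound 2 (0.15 log units; within the scatter) stayed within the scatter, a small gain at most is expected, roughly a 1.5-fold lower number from compound 1 to compound 4 (0.18 log units; within the scatter). Compound 4 is therefore estimated at 550 nM, with a plausible range from 220 nM to 1400 nM.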

Compound 4, half-maximal inhibitory concentration: 930 nM
The estimate for compound 4 lay 1.7-fold (0.23 log units) below the measured number, within the range that was stated.
By their numbers in this assay, from the lowest: compound 3; then compounds 1, 4 and 2 (each within the scatter of the next).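

Adding 2-hydroxyethyl to the oxygen of compound 3 gives a 2.6-fold higher number from compound 3 to compound 4 (0.41 log units; beyond the scatter), so the advantage of 1-hydroxyethyl at this position does not carry over to the longer ether chain. The other two steps, a 1.1-fold higher number from compound 1 to compound 4 (0.05 log units; within the scatter) and a 1.3-fold lower number from compound 2 to compound 4 (0.10 log units; within the scatter), stay within the scatter, so 1-(2-hydroxyethoxy)ethyl cannot be told apart from butyl or 2-hydroxyethyl here. No measurement shown explains these results.

Still open, on these data alone, is whether the ether oxygen, the added length or the terminal hydroxy accounts for the step from compound 3. A methoxy or an amine at the end of the chain could help separate these.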